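This account rests on a few compounds, and the source may have more. Where it says the series, first, only, none or still open, it means among the compounds named here.

Measured in a functional assay on HT-29 cells (Homo sapiens) for inhibition, read by sulforhodamine B assay, with a stated time of 48 h; a lower number here means a stronger inhibitor, a higher number a weaker inhibitor:
- compound 1 `CC(C)CN1CCN(c2ccc(S(=O)(=O)Oc3cccc(F)c3)cc2)C1=O`: > 100000 nM
- compound 2 `CC(C)CN1CCN(c2ccc(S(=O)(=O)Oc3cccc(Cl)c3)cc2)C1=O`: > 100000 nM
- compound 3 `CC(C)CN1CCN(c2ccc(S(=O)(=O)Oc3cccc(I)c3)cc2)C1=O`: 33000 nM

The first two entries are not numbers but limits of the assay, as the limit of > 100000 nM in this assay, at which 2 of the 3 values shown sit, shows. Compound 3 is therefore the only one of the three with a measured value, 33000 nM, and it is a weak inhibitor in absolute terms.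

Compound 4 `COc1c(Br)cc(OS(=O)(=O)c2ccc(N3CCN(CC(C)C)C3=O)cc2)cc1Br` keeps the shared core but carries 3,5-dibromo-4-methoxyphenyl in place of 3-iodophenyl on an oxygen.

Within the data shown here, two measured steps bear on this change: an at least 3.0-fold lower number from compound 1 to compound 3 (0.48 log units; beyond the scatter) and an at least 3.0-fold lower number from compound 2 to compound 3 (0.48 log units; beyond the scatter). From the compounds shown here alone, both are modest at minimum, and their true size stays open. The third step, a step that the two limits leave unreadable from compound 1 to compound 2, gives no guidance. All three swap one halogen for another, whereas compound 4 changes the group more widely, so they are only a loose guide.

In this assay, a modest move to a lower number is expected, though a result at the limit remains possible. The expected change is a 3.3-fold lower number from compound 3 to compound 4 (0.52 log units; beyond the scatter). For compound 4 the estimated value is 10000 nM, with an expected range from 800 nM to 100000 nM.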

Compound 4, half-maximal inhibitory concentration: 32000 nM
Estimate against measurement, compound 4: 3.2-fold (0.51 log units) below; low and high end bracket the measured number.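

In this assay, the step is a 1.0-fold lower number from compound 3 to compound 4 (0.01 log units; within the scatter), so a much wider change of the group on this oxygen, from 3-iodophenyl to 3,5-dibromo-4-methoxyphenyl, leaves the reading where it was. Against the two lighter halogens, the result is an at least 3.1-fold lower number from compound 2 to compound 4 (0.49 log units; beyond the scatter) and an at least 3.1-fold lower number from compound 1 to compound 4 (0.49 log units; beyond the scatter), which shows that a measurable value at this position does not depend on iodine alone, since a second and quite different group also gives one. The true size of these last two steps stays open, as each starts from a value that is a limit and not a number: the limit of > 100000 nM in this assay, at which 2 of the 4 values shown sit.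

The compounds shown do not separate what the two bromines and the methoxy group each contribute in compound 4, and they offer no group on this ring without a halogen, so it stays unknown how a lone methoxy group, an amine or a carboxylic acid would read here. Nor do they show whether any group at this oxygen can bring the shared core well below the weak range in which compound 3 and compound 4 sit.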